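Sulfamate series: varying the amino substituent on the benzamide

This account rests on a few compounds, and the source may have more. Where it says the series, first, only, none or still open, it means among the compounds named here.

Compound 2 `CCN(Cc1ccc(Br)cc1)c1cccc(C(=O)N2CCc3ccc(OS(N)(=O)=O)cc3C2)c1` stands highest of the two numbers in an assay on HEK293 cells for inhibition of Steryl-sulfatase (Homo sapiens), tested at 1 uM (on this read-out higher numbers stand for a stronger effect at the one concentration tested and lower numbers for a weaker effect), giving 84.5%. Compound 1 `NS(=O)(=O)Oc1ccc2c(c1)CN(C(=O)c1cccc(N3CCC(N4CCCCC4)CC3)c1)CC2` gives 8% in this assay, a gap beyond the scatter. Compound 3 `CCCN(Cc1ccccc1)c1cccc(C(=O)N2CCc3ccc(OS(N)(=O)=O)cc3C2)c1` is not yet measured; it differs from compound 2 by benzyl(propyl)amino in place of (4-bromobenzyl)(ethyl)amino on an aromatic carbon. Going by the values given here, no step between measured compounds matches this change, so the expectation rests on compound 2 alone. Because compound 2 gives 84.5%, a modest downward step, possibly within the scatter, is expected, a number 14.5 percentage points lower from compound 2 to compound 3 (beyond the scatter). For compound 3 the estimate in this assay is 70%, with a range from 45% to 90%.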

Compound 3, a percentage reported as inhibition, at one concentration (the size of the read-out at that concentration, not a potency): 67.4%
Compound 3: the middle estimate sits 2.6 percentage points above what was measured; measured number inside the range.
By their numbers in this assay, from the lowest: compound 1; then compound 3; then compound 2.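

In this assay, benzyl(propyl)amino in place of (4-bromobenzyl)(ethyl)amino gives a number 17.1 percentage points lower from compound 2 to compound 3 (beyond the scatter), so a high read-out at this position does not depend on the bromine, although the step is real. Compound 3 also remains well above compound 1 at 8%. Nothing measured here explains the step.

The change alters the ring substituent and the chain together, so the compounds shown cannot assign the step to either one. From the compounds shown here alone, a chlorine on the benzyl ring or a butyl chain on the nitrogen remains open.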